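The source may report more compounds than this note shows. Statements on the series, on what has been measured and on what is new or still open speak of the compounds shown alone.

Three compounds share one core and differ only in the ring that sits at its far end. In an assay on HEK293 cells for inhibition of N-acylethanolamine-hydrolyzing acid amidase (Rattus norvegicus), read by LC-MS, with a stated time of 30 min (on this read-out higher numbers stand for weaker inhibition and lower numbers for stronger inhibition), compound 1, `Cc1ccc(-c2ccc(CCC(=O)N3CCCC3)cc2)cc1`, gives 33200 nM; compound 2, `O=C(CCc1ccc(-c2ccc(F)cc2)cc1)N1CCCC1`, gives 3400 nM; and compound 3, `O=C(CCc1ccc(-c2ccsc2)cc1)N1CCCC1`, gives 2500 nM. Compound 3 carries the lowest of the three numbers, though its gap to compound 2 lies within the scatter, so the two cannot be told apart; only compound 1 stands clearly apart, as shown by a 13-fold lower number from compound 1 to compound 3 (1.12 log units; beyond the scatter) and a 9.8-fold lower number from compound 1 to compound 2 (0.99 log units; beyond the scatter), while a 1.4-fold lower number from compound 2 to compound 3 (0.13 log units; within the scatter) is within the scatter. Compound 4, `O=C(CCc1ccc(C2CCCCC2)cc1)N1CCCC1`, is not yet measured. It differs from compound 3 in one place: cyclohexyl in place of thiophen-3-yl on an aromatic carbon. Going by the values given here, none of the measured steps swaps an aromatic ring for a non-aromatic one, so they bear on this change only loosely: they show that the far ring can move the number a great deal in one case and hardly at all in another. A step of a 1.6-fold higher number from compound 3 to compound 4 (0.20 log units; within the scatter) is therefore expected, small and not clearly beyond the scatter. For compound 4 the estimate in this assay is 4000 nM, with a range from 1500 nM to 15000 nM.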

Compound 4, half-maximal inhibitory concentration: 500 nM
Compound 4: middle estimate off by 8.0-fold (0.90 log units), on the high side; measured number below the stated range.
By their numbers in this assay, from the lowest: compound 4; then compounds 3 and 2 (each within the scatter of the next); then compound 1.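

Cyclohexyl, a non-aromatic ring of carbon only, gives a 5.0-fold lower number from compound 3 to compound 4 (0.70 log units; beyond the scatter) and also a 6.8-fold lower number from compound 2 to compound 4 (0.83 log units; beyond the scatter) as well as a 66-fold lower number from compound 1 to compound 4 (1.82 log units; beyond the scatter), so compound 4 has the lowest number of the four and is the strongest inhibitor among them. The earlier steps shown here only exchanged one aromatic far ring for another, and these new steps show that an aromatic ring is not needed at this position to reach a lower number. Nothing measured here explains why this ring does better.

Cyclohexyl differs from thiophen-3-yl in ring size, in aromatic character and in the loss of sulfur all at once, so these three changes cannot be separated here. Going by these compounds, it also remains open whether a straight hexyl chain, or an amine on the cyclohexyl ring, would keep the number this low.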